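Swapping one ring group: from compound 3 to compound 4

This account rests on a few compounds, and the source may have more. Where it says the series, first, only, none or still open, it means among the compounds named here.

Values in an ADME assay (liver) for metabolic stability, with Liver microsome (Homo sapiens) as the target, using microsomes and NADPH, with a stated time of 30 min, tested at 1 uM; on this read-out higher numbers stand for fast clearance and lower numbers for slow clearance:
Compound 1 `CC(C)(O)C#Cc1cc(C(O)(C(F)(F)F)C(F)(F)F)cnc1N1CCN(S(=O)(=O)c2ccc(N)nc2)CC1`: < 14 mL.min-1.g-1, a limit of the assay
Compound 2 `CC(C)(C)n1cc(-c2cc(C(O)(C(F)(F)F)C(F)(F)F)cnc2N2CCN(S(=O)(=O)c3ccc(N)nc3)CC2)cn1`: 86 mL.min-1.g-1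
Compound 3 `Cc1ccc(-c2cc(C(O)(C(F)(F)F)C(F)(F)F)cnc2N2CCN(S(=O)(=O)c3ccc(N)nc3)CC2)cn1`: 43 mL.min-1.g-1

Compound 3 has one numerical neighbour, and the gap to it is a 2.0-fold lower number from compound 2 to compound 3 (0.30 log units; within the scatter). Two further steps start from the limit: an at least 3.0-fold higher number from compound 1 to compound 3 (0.48 log units; beyond the scatter) and an at least 6.1-fold higher number from compound 1 to compound 2 (0.78 log units; beyond the scatter).

Compound 4 `Nc1ccc(S(=O)(=O)N2CCN(c3ncc(C(O)(C(F)(F)F)C(F)(F)F)cc3-c3ccc4[nH]ncc4c3)CC2)cn1` differs at the same position, with 1H-indazol-5-yl in place of 6-methylpyridin-3-yl on an aromatic carbon. Both steps from the limit replace 3-hydroxy-3-methylbut-1-yn-1-yl, a different kind of change. The closer guide is the exchange between two ring groups, a 2.0-fold lower number from compound 2 to compound 3 (0.30 log units; within the scatter), so no change beyond the scatter is expected. The expected change is a 1.1-fold lower number from compound 3 to compound 4 (0.03 log units; within the scatter). Compound 4 is estimated at 40 mL.min-1.g-1, within an expected range of 18 mL.min-1.g-1 to 90 mL.min-1.g-1.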

Compound 4, intrinsic clearance in microsomes: 27 mL.min-1.g-1
Beside the measured number, compound 4's estimate is 1.5-fold (0.17 log units) above it; measured number inside the range.
By their numbers in this assay, from the lowest: compounds 4, 3 and 2 (each within the scatter of the next, the first and the last beyond it). At a limit, below all of these: compound 1.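

In this assay, 1H-indazol-5-yl, which brings a hydrogen-bond donor, leaves compound 4 level with compound 3: a 1.6-fold lower number from compound 3 to compound 4 (0.20 log units; within the scatter). For the compounds shown here, exchanging 1-(tert-butyl)-1H-pyrazol-4-yl for it, however, gives a 3.2-fold lower number from compound 2 to compound 4 (0.50 log units; beyond the scatter), the first exchange between two ring groups at this position to pass the scatter. Against 3-hydroxy-3-methylbut-1-yn-1-yl the result is only an at least 1.9-fold higher number from compound 1 to compound 4 (0.28 log units; that floor lies within the scatter), a floor that starts from a limit.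

Going by these compounds, whether an amine or a carboxylic acid on the ring group would change the clearance stays open. The true value of compound 1 also stays open: the limit of < 14 mL.min-1.g-1 in this assay, at which 1 of the 4 values shown sits.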